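Swapping an aryl amide for an amine chain

A few compounds are considered here, and "the series" means these few. Any claim that something is new, unique, unknown or untested is made for them only; others in the source may bear on it.

All three measured compounds share one core and were tested in an assay on isolated protein for inhibition of glutathione S-transferase P (Homo sapiens), with a stated time of 10 min; on this read-out lower numbers stand for stronger inhibition and higher numbers for weaker inhibition. Their results:

compound 1, `O=C(CCC(=O)OCCCCCCSc1ccc([N+](=O)[O-])c2nonc12)Nc1ccccc1Cl`, gives 15500 nM
compound 2, `O=C(CCC(=O)OCCCCCCSc1ccc([N+](=O)[O-])c2nonc12)Nc1ccc(Br)cc1`, gives 5090 nM
compound 3, `O=C(CCC(=O)OCCCCCCSc1ccc([N+](=O)[O-])c2nonc12)Nc1ccc(F)c(Cl)c1`, gives 9850 nM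

The three differ only in the substituted phenyl on the amide nitrogen. Compound 3 is hard to place: the step of a 1.6-fold lower number from compound 1 to compound 3 (0.20 log units; within the scatter) is within the scatter, as is a 1.9-fold higher number from compound 2 to compound 3 (0.29 log units; within the scatter), so only a 3.0-fold lower number from compound 1 to compound 2 (0.48 log units; beyond the scatter) stands out, and even that is modest.

Compound 4, `CN(C)CCCNC(=O)CCC(=O)OCCCCCCSc1ccc([N+](=O)[O-])c2nonc12`, goes a different way: 3-(dimethylamino)propyl in place of 3-chloro-4-fluorophenyl on an amide-type nitrogen. Every measured step swaps one substituted phenyl for another; none removes the ring for a chain of this kind, so none bears directly on this change. The largest of them, a 3.0-fold lower number from compound 1 to compound 2 (0.48 log units; beyond the scatter), shows how little these aryl swaps moved the number. Going by the values given here, with no direct precedent, the expectation for compound 4 is a weak-to-absent shift, leaning toward a higher number, with a wide range: a 1.5-fold higher number from compound 3 to compound 4 (0.18 log units; within the scatter) is estimated, giving an expected 15000 nM for compound 4, from 4000 nM to 60000 nM.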

Compound 4, half-maximal inhibitory concentration: 160 nM
The estimate for compound 4 lay 94-fold (1.97 log units) above the measured number; measured number below the stated range.
By their numbers in this assay, from the lowest: compound 4; then compounds 2, 3 and 1 (each within the scatter of the next, the first and the last beyond it).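

The group on this amide-type nitrogen matters far more than the phenyl swaps suggested: putting 3-(dimethylamino)propyl in place of the ring gives a 62-fold lower number from compound 3 to compound 4 (1.79 log units; beyond the scatter) and a 32-fold lower number from compound 2 to compound 4 (1.50 log units; beyond the scatter) as well as a 97-fold lower number from compound 1 to compound 4 (1.99 log units; beyond the scatter) in a large move that holds whichever phenyl leaves. These steps make compound 4 the strongest inhibitor of the four, so an aromatic ring is not needed at this position for inhibition. Nothing available here explains why the chain does so much better.

The change removes the ring and adds an amine at once, so the compounds shown cannot say which of the two drives the gain. A plain butyl chain with no amine, a longer chain ending in the same dimethylamino group, or a chain ending in a carboxylic acid could begin to separate them.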